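Fluoro to Chloro on a Core Sitting at the Limit

This account rests on a few compounds, and the source may have more. Where it says the series, first, only, none or still open, it means among the compounds named here.

Two measured compounds share one core and differ only in a single group on an aromatic carbon. Compound 1 `Cc1ccc2c(c1)C1(C(=O)N2Cc2ccccc2)C(C#N)=C(N)Oc2cc3oc(-c4ccccc4)cc(=O)c3c(O)c21` carries a methyl group there. In a functional assay on K562 cells (Homo sapiens) for antiproliferative activity, read by MTT assay, with a stated time of 48 h (a higher number here means a weaker inhibitor, a lower number a stronger inhibitor), compound 1 gives > 50000 nM, which is a limit of the assay rather than a number. Compound 2 `N#CC1=C(N)Oc2cc3oc(-c4ccccc4)cc(=O)c3c(O)c2C12C(=O)N(Cc1ccccc1)c1ccc(F)cc12` carries a fluoro group in the same place. In this assay compound 2 gives > 50000 nM, again a limit of the assay. The step that the two limits leave unreadable from compound 1 to compound 2 therefore has no readable size because of the limit of > 50000 nM in this assay, at which 2 of the 2 values shown sit.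

Compound 3 `N#CC1=C(N)Oc2cc3oc(-c4ccccc4)cc(=O)c3c(O)c2C12C(=O)N(Cc1ccccc1)c1ccc(Cl)cc12` is the unmeasured member, with chloro in place of fluoro on an aromatic carbon. Going by the values given here, the only measured step that bears on this change, a step that the two limits leave unreadable from compound 1 to compound 2, gives no size, so no direction can be drawn from it. Compound 3 is expected to give about 60000 nM, estimated to lie between 20000 nM and 200000 nM, most likely again reported as a limit. The expected step that the limit leaves unreadable from compound 2 to compound 3 is accordingly estimated as none beyond the scatter.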

Compound 3, half-maximal inhibitory concentration: 36300 nM
Beside the measured number, compound 3's estimate is 1.7-fold (0.22 log units) above it, within the range that was stated.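

In this assay, going by these compounds alone, compound 3 gives 36300 nM, the first value in this set that is a number rather than a limit, so with chloro on this aromatic carbon the read-out falls within what the assay can report. The change from fluoro gives an at least 1.3-fold lower number from compound 2 to compound 3 (0.13 log units; that floor lies within the scatter), and the change from methyl gives an at least 1.3-fold lower number from compound 1 to compound 3 (0.13 log units; that floor lies within the scatter). Each of these is only a floor, and no gain beyond the scatter can be claimed from either, with the true size left open because the starting compounds give no number: the limit of > 50000 nM in this assay, at which 2 of the 3 values shown sit.

The step from methyl to fluoro still cannot be read. The compounds shown leave open whether a bromo group, a methoxy group or an amine on this same aromatic carbon would give a lower number than chloro does, and by how much.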